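The source may hold more compounds than are shown below. What is called first, only, known or untested is meant among the compounds shown, and "the series" means these compounds.

Three compounds have been measured in an assay on mitochondria for inhibition of Amine oxidase [flavin-containing] A (Bos taurus); a lower number here means a stronger inhibitor, a higher number a weaker inhibitor:

compound 1, `Cc1csc(N/N=C/c2ccc(Cl)cc2Cl)n1`, gives 12 nM
compound 2, `Clc1ccc(/C=N/Nc2nc(-c3ccccc3)cs2)c(Cl)c1`, gives 93.3 nM
compound 3, `COc1ccc(/C=N/Nc2nc(C)cs2)cc1`, gives 19.1 nM

Compound 1 and compound 2 share a core and differ in one place: phenyl in place of methyl on an aromatic carbon. This change made a 7.8-fold higher number from compound 1 to compound 2 (0.89 log units; beyond the scatter). Compound 3 is built on another core; the difference between the core of compound 3 and the core of compound 1 is not broken down here. The values of compound 1 and compound 3 lie within the scatter of each other, while compound 2 stands apart from both beyond the scatter.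

Compound 4, `COc1ccc(/C=N/Nc2nc(-c3ccccc3)cs2)cc1`, has not yet been measured. It differs from compound 3 by phenyl in place of methyl on an aromatic carbon. The place is described in the same words for both pairs, so this is the same change carried onto a second core. Within the data shown here, only one earlier instance of it exists, so the expectation rests on that alone. Compound 4 is expected to show a 7.9-fold higher number from compound 3 to compound 4 (0.90 log units; beyond the scatter), because the same change earlier made a 7.8-fold higher number from compound 1 to compound 2 (0.89 log units; beyond the scatter). The estimate for compound 4 in this assay is 150 nM, with a likely range from 50 nM to 450 nM.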

Compound 4, inhibition constant: 50.1 nM
Compound 4: the middle estimate sits 3.0-fold (0.48 log units) above what was measured; measured number inside the range.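

Phenyl in place of methyl gave a 2.6-fold higher number from compound 3 to compound 4 (0.42 log units; beyond the scatter) in this assay, so the number rose on the core of compound 3 as it had on the core of compound 1. The direction of the change therefore carried from one core to the other, but two cores are too few to make it a rule for the series, and these numbers do not show why the number rises. The size of the step did not carry over, and a value from one core would have overstated or understated the step on the other, as the two steps differ by more than the scatter: the same change on two cores in this assay, a 7.8-fold higher number (0.89 log units; beyond the scatter) from compound 1 to compound 2 and a 2.6-fold higher number (0.42 log units; beyond the scatter) from compound 3 to compound 4, 3.0-fold (0.47 log units) apart, beyond the scatter of two such steps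

The compounds shown hold only methyl or phenyl at this place, so it stays open how an amine, a carboxylic acid or a longer chain would behave there. Going by these compounds, it also stays open which size of step a third core would show, and whether it would even keep the same direction.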